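Adding a Propyl Group to Compound 2

A few compounds are considered here, and "the series" means these few. Any claim that something is new, unique, unknown or untested is made for them only; others in the source may bear on it.

Among the compounds with values here, in a functional assay on MCF7 cells (Homo sapiens) for inhibition, read by sulforhodamine B assay, with a stated time of 48 h (on this read-out higher numbers stand for weaker inhibition of growth and lower numbers for stronger inhibition of growth), compound 3 `O=C(/C=C/c1ccc(F)cc1)c1ccc(O)cc1O` gives 7300 nM, the only number available. Compound 2 `COc1ccc(/C=C/C(=O)c2ccc(O)cc2O)cc1` stands at "not determined" (no result reported), so it has no place on the scale. Compound 1 `O=C(/C=C/c1ccc(C(F)(F)F)cc1)c1ccc(O)cc1O` likewise stands at "not determined" (no result reported). Compound 4 `CCCc1c(O)ccc(C(=O)/C=C/c2ccc(OC)cc2)c1O` is reached by one change: propyl in place of hydrogen on an aromatic carbon. Within the data shown here, no measured pair shows a step of this kind, so its size is uncertain. A modest step towards stronger inhibition of growth in this assay is expected, though none beyond the scatter remains possible. Among the measured compounds shown here, the only anchor is compound 3 at 7300 nM. For compound 4 the expected value is 4000 nM, within an estimated range of 1200 nM to 15000 nM.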

Compound 4, concentration for 50% growth inhibition: 13300 nM
Estimate against measurement, compound 4: 3.3-fold (0.52 log units) below; the measured number falls inside the stated range.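

Compound 2 has no single number in this assay, so the step to compound 4 cannot be read. On these data alone, whether propyl in place of hydrogen strengthens or weakens inhibition of growth stays open. No measured evidence bears on the result.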